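The source may report more compounds than this note shows. Statements on the series, on what has been measured and on what is new or still open speak of the compounds shown alone.

Measured compounds in hand:

- compound 1, `O=C(O)CC(NC(=O)c1c(Cl)cccc1Cl)c1ccccc1`: > 100000 nM
- compound 2, `O=C(O)CC(NS(=O)(=O)c1ccccc1)c1ccccc1`: > 100000 nM
- compound 3, `CC(C)(C)c1ccc(C(CC(=O)O)NC(=O)c2c(Cl)cccc2Cl)cc1`: > 100000 nM

Every value above is a limit of the assay and not a number. In a functional assay on MDA-MB-436 cells (Homo sapiens) for antiproliferative activity, read by MTT assay, with a stated time of 24 h (a higher number here means a weaker inhibitor, a lower number a stronger inhibitor), compound 1 reaches only the limit > 100000 nM. In this assay compound 2 likewise gives only the limit > 100000 nM. For compound 3 the reading in this assay is again the limit > 100000 nM. Within the data shown here, the one structural change that is made between measured compounds is tert-butyl in place of hydrogen on an aromatic carbon, and the step it makes is a step that the two limits leave unreadable from compound 1 to compound 3. The difference between the core of compound 1 and the core of compound 2 is not broken down here.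

Compound 4, `CC(C)(C)c1ccc(C(CC(=O)O)NS(=O)(=O)c2ccccc2)cc1`, stands to compound 2 as compound 3 stands to compound 1: the change is tert-butyl in place of hydrogen on an aromatic carbon. The two place descriptions agree word for word, so this is the same change applied to the other core.

What is known across the set is the limit of > 100000 nM in this assay, at which 3 of the 3 values shown sit. With no readable step and no value anywhere in the series, the expected step from compound 2 to compound 4 in this assay is a step that the limit leaves unreadable from compound 2 to compound 4, resting on the fact that the same change gave a step that the two limits leave unreadable from compound 1 to compound 3. For compound 4 in this assay the expected result is 200000 nM, with the likely range from 100000 nM to 1000000 nM, and the most probable outcome is that the assay again reports only a limit.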

Compound 4, half-maximal inhibitory concentration: > 100000 nM
Compound 4 ended at the assay's limit; the forecaster's own chance of this, stated with the estimate: 85%; the middle value is on the limit's open side.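

In this assay compound 4 gives > 100000 nM, a limit of the assay and not a number. Compound 2 also stands at a limit, so no step can be read between compound 2 and compound 4. The compounds shown leave open whether tert-butyl in place of hydrogen changes activity on either core, as the only reading across the series is this: the limit of > 100000 nM in this assay, at which 4 of the 4 values shown sit.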